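Urea-to-amide change on a pyrazole urea series

A few compounds are considered here, and "the series" means these few. Any claim that something is new, unique, unknown or untested is made for them only; others in the source may bear on it.

Measured so far:
- compound 1 `O=C(Nc1cccc(-n2cc(-c3ccncc3)c(-c3cc(O)cc(Cl)c3)n2)c1)Nc1ccc(Cl)c(C(F)(F)F)c1`, 10.5%
- compound 2 `COc1cc(Cl)cc(-c2nn(-c3cccc(NC(=O)Nc4ccc(Cl)c(C(F)(F)F)c4)c3)cc2-c2ccncc2)c1`, 0.3%
- compound 3 `COc1cc(Cl)cc(-c2nn(-c3cccc(NC(=O)Nc4cc(C(F)(F)F)cc(C(F)(F)F)c4)c3)cc2-c2ccncc2)c1`, -6.14%

All three were tested in a functional assay on NCI-H23 cells (Homo sapiens) for inhibition, read by sulforhodamine B assay, with a stated time of 48 h, tested at 10 uM; a lower number here means a stronger effect, a higher number a weaker effect of the compound at the concentration tested. Compound 2 stands second highest of the three; its nearest neighbour is compound 3, whose value lies within the scatter, while compound 1 lies beyond the scatter above it. For the measured compounds named here, the one measured step, a number 10.2 percentage points lower from compound 1 to compound 2 (beyond the scatter), is modest and concerns methyl in place of hydrogen on an oxygen on an aromatic ring.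

Compound 4 `COc1cc(Cl)cc(-c2nn(-c3cccc(NC(=O)c4cccc(C(F)(F)F)c4)c3)cc2-c2ccncc2)c1` is not yet measured. It differs from compound 2 by 3-(trifluoromethyl)phenyl in place of (4-chloro-3-(trifluoromethyl)phenyl)amino on a carbonyl carbon whose other neighbour is an amide-type nitrogen. Going by the values given here, no measured step touches this part of the molecule, so the data give no direct guide to its size or direction. The expectation for compound 4 is therefore anchored on compound 2 with a wide range, estimated as a step of a number 14.7 percentage points higher from compound 2 to compound 4 (beyond the scatter). Compound 4 is thus expected to give about 15%, between -10% and 50%.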

Compound 4, a percentage reported as activity, at one concentration (the size of the read-out at that concentration, not a potency): 55.7%
Estimate against measurement, compound 4: 40.7 percentage points below, and the stated range ends below it.
By their numbers in this assay, from the lowest: compounds 3 and 2 (each within the scatter of the next); then compound 1; then compound 4.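

In this assay, the group on the carbonyl carbon proves to be a far more sensitive place than the oxygen on the aromatic ring: the change there is large, a number 55.4 percentage points higher from compound 2 to compound 4 (beyond the scatter), whereas the change on the oxygen is modest, a number 10.2 percentage points lower from compound 1 to compound 2 (beyond the scatter). The effect of the compound at the concentration tested is largely lost in this step, which turns the urea into an amide and also removes the chlorine, so a single step cannot show which of the two losses matters. Nothing available here explains the loss.

The compounds shown leave open whether a urea carrying a plain 3-(trifluoromethyl)phenyl would keep the effect, or an amide carrying the chlorine would regain it. They also leave open whether a methylene in place of the amino nitrogen would behave like the urea or like the amide.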